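Oral exposure in the series: from compound 2 to compound 3

This account rests on a few compounds, and the source may have more. Where it says the series, first, only, none or still open, it means among the compounds named here.

In an ADME assay on the whole organism for pharmacokinetics, with Mus musculus as the target, at a dose of 10 mg/kg by the oral route (on this read-out higher numbers stand for higher exposure at the dose given and lower numbers for lower exposure), compound 1 `CC/C(=C(/c1ccc(/C=C/C(=O)O)cc1)c1ccc2[nH]ccc2c1)c1ccccc1` gives 9400 ng.h/mL and compound 2 `CC/C(=C(/c1ccc(/C=C/C(=O)O)cc1)c1ccc2[nH]ncc2c1)c1cccc(Cl)c1` gives 11000 ng.h/mL and these two values lie within the usual scatter of each other. Compound 3 `CC/C(=C(/c1ccc(/C=C/C(=O)O)cc1)c1ccc2[nH]ncc2c1)c1cscc1C` has 4-methylthiophen-3-yl in place of 3-chlorophenyl on a double-bonded chain carbon bound to a double-bonded chain carbon and a saturated chain carbon, with 4-methylthiophen-3-yl in place of 3-chlorophenyl on a double-bonded chain carbon bound to a double-bonded chain carbon and a saturated chain carbon as the counted difference. For the measured compounds named here, no measured pair isolates this change, so no step beyond the scatter is expected in this assay here. The estimated step is a 1.4-fold lower number from compound 2 to compound 3 (0.14 log units; within the scatter) and stays within the scatter. For this assay compound 3 is estimated at 8000 ng.h/mL with a range from 3000 ng.h/mL to 20000 ng.h/mL as the expected spread.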

Compound 3, area under the concentration-time curve: 3800 ng.h/mL
Compound 3: middle estimate off by 2.1-fold (0.32 log units), on the high side; low and high end bracket the measured number.
By their numbers in this assay, from the lowest: compound 3; then compounds 1 and 2 (each within the scatter of the next).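

For the compounds shown here, the group on the double-bonded chain carbon bound to a double-bonded chain carbon and a saturated chain carbon matters for oral exposure: in this assay, 4-methylthiophen-3-yl in place of 3-chlorophenyl gives a 2.9-fold lower number from compound 2 to compound 3 (0.46 log units; beyond the scatter) and is the first single-place change that can be read. The change swaps a six-membered carbon ring for a five-membered ring with one hetero atom and adds a hydrogen-bond acceptor by the count. No supporting measurement bears on what lies behind this step.

From the compounds shown here alone, it remains open whether the lower number follows the ring or its methyl group. A plain thiophen-3-yl or a 3-methylphenyl at this place would separate the two.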